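Swapping the aromatic ring for cyclohexyl at the sulfur-linked chain

The source may hold more compounds than are shown below. What is called first, only, known or untested is meant among the compounds shown, and "the series" means these compounds.

Compound 1 `Cc1cc(Nc2cc(-c3ccccc3)[nH]n2)n2nc(SCc3c(Cl)cccc3Cl)nc2n1` gives 5280 nM
Compound 2 `Cc1cc(Nc2cc(-c3ccccc3)[nH]n2)n2nc(SCc3cccc4ccccc34)nc2n1` gives 3120 nM
Compound 3 `Cc1cc(Nc2cc(-c3ccccc3)[nH]n2)n2nc(SCc3ccc(Br)cc3)nc2n1` gives 1110 nM

All three share one core and differ only in the group on a saturated chain carbon bound to a sulfur, measured in a functional assay on MGC-803 cells (Homo sapiens) for inhibition, read by MTT assay, with a stated time of 72 h; a higher number here means a weaker inhibitor, a lower number a stronger inhibitor. Compound 3 has the lowest number: a 4.8-fold lower number from compound 1 to compound 3 (0.68 log units; beyond the scatter) and a 2.8-fold lower number from compound 2 to compound 3 (0.45 log units; beyond the scatter) both lie beyond the scatter, so compound 3 is the strongest inhibitor of the three, while a 1.7-fold lower number from compound 1 to compound 2 (0.23 log units; within the scatter).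

Compound 4 `Cc1cc(Nc2cc(-c3ccccc3)[nH]n2)n2nc(SCC3CCCCC3)nc2n1` carries a different kind of change: cyclohexyl in place of 4-bromophenyl on a saturated chain carbon bound to a sulfur. Within the data shown here, no measured step exchanges an aromatic ring for a non-aromatic one, so the three steps give only a sense of scale, all modest. A modest rise is therefore expected, a 2.3-fold higher number from compound 3 to compound 4 (0.35 log units; beyond the scatter). Compound 4 is estimated at 2500 nM, within 800 nM to 8000 nM.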

Compound 4, half-maximal inhibitory concentration: 12600 nM
The estimate for compound 4 lay 5.0-fold (0.70 log units) below the measured number, outside the stated range (above it).
By their numbers in this assay, from the lowest: compound 3; then compounds 2 and 1 (each within the scatter of the next); then compound 4.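

In this assay cyclohexyl gives a higher number than each aromatic group on the saturated chain carbon bound to a sulfur: the steps are an 11-fold higher number from compound 3 to compound 4 (1.06 log units; beyond the scatter) and a 4.0-fold higher number from compound 2 to compound 4 (0.61 log units; beyond the scatter) and a 2.4-fold higher number from compound 1 to compound 4 (0.38 log units; beyond the scatter) and all lie beyond the scatter, so compound 4 is the weakest inhibitor of the four. Among these compounds, the step away from 4-bromophenyl is the largest seen at this position so far. No measurement given here explains this loss.

From the compounds shown here alone, the aromatic ring and the bromine leave together in this change, so their separate contributions stay open. An unsubstituted phenyl group at the same place would help to separate them.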